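Aryl-amino core series: hydrogen for ethyl on the side chain

The source may hold more compounds than are shown below. What is called first, only, known or untested is meant among the compounds shown, and "the series" means these compounds.

Measured so far in a functional assay on MCF7 cells (Homo sapiens) for inhibition, read by sulforhodamine B assay; a higher number here means a weaker inhibitor, a lower number a stronger inhibitor:
compound 1 `CCCc1ccc(NC2=CC(=O)c3c(nc4n3[C@H]3OC[C@@H](O)[C@H]3OC4)C2=O)cc1` — > 4000 nM
compound 2 `O=C1C=C(Nc2ccc(C(F)(F)F)cc2)C(=O)c2c1nc1n2[C@H]2OC[C@@H](O)[C@H]2OC1` — > 4000 nM

In this assay compound 1 gives > 4000 nM; this is a limit of the assay, not a number. Compound 2 likewise gives > 4000 nM in this assay, again a limit. Within the data shown here, both values sit at the limit of > 4000 nM in this assay, at which 2 of the 2 values shown sit, so compound 1 stands only on a limit, and no measured step between compounds joins it to any other. The two measured compounds differ in more than one place and are not compared here beyond noting that each shows only a limit.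

Compound 3 `Cc1ccc(NC2=CC(=O)c3c(nc4n3[C@H]3OC[C@@H](O)[C@H]3OC4)C2=O)cc1` is not yet measured. It differs from compound 1 as follows: hydrogen in place of ethyl on a saturated chain carbon bound to an aromatic carbon. Among the measured compounds shown here, with no measured step available for this change, nothing points to a gain in inhibition. The step expected is a step that the limit leaves unreadable from compound 1 to compound 3, that is, no change beyond the usual scatter, since compound 1 itself gives only > 4000 nM. Compound 3 is therefore estimated at 6000 nM, with a range from 2000 nM to 20000 nM, and most probably this assay will again report only a limit.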

Compound 3, half-maximal inhibitory concentration: > 4000 nM
Compound 3 gave a limit, no number; the forecaster's own chance of this, stated with the estimate: 75%; the middle value is on the limit's open side.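

No step can be read between compound 1 and compound 3 in this assay, since each stands only on a limit of the assay, not a number: the limit of > 4000 nM in this assay, at which 3 of the 3 values shown sit.

The compounds shown leave open whether any aryl-amino compound in this series gives a readable value in this assay, and what hydrogen in place of ethyl does to inhibition.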